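The source may report more compounds than this note shows. Statements on the series, on what has been measured and on what is new or still open speak of the compounds shown alone.

Compound 1 `Cc1cc(C)cc(S(=O)(=O)c2c(C(=O)NC(C)C(=O)NC(C)c3ccncc3)[nH]c3ccc(Cl)cc23)c1` in an ADME assay on MT4 cells (Homo sapiens) for cytotoxicity, read by MTT assay (a lower number here means that less compound is tolerated, a higher number that more compound is tolerated), gives 21900 nM.
Compound 2 `Cc1cc(C)cc(S(=O)(=O)c2c(C(=O)NCC(=O)NCc3ccncc3)[nH]c3ccc(Cl)cc23)c1` in this assay gives only a limit of > 48900 nM.
Compound 3 `Cc1cc(C)cc(S(=O)(=O)c2c(C(=O)NCC(=O)NCc3ccncn3)[nH]c3ccc(Cl)cc23)c1` in this assay gives only a limit of > 48800 nM.

Going by the values given here, compound 1 stands as the only compound here with a measured number; the two others come with limits rather than values, and nothing can be said of its rank among them. Compound 4 `Cc1cc(C)cc(S(=O)(=O)c2c(C(=O)NC(C)C(=O)NCCn3c(C)cnc3[N+](=O)[O-])[nH]c3ccc(Cl)cc23)c1` differs from compound 1 in one place: a group of 11 heavy atoms (6 carbon, 3 nitrogen, 2 oxygen; one five-membered aromatic ring with 2 hetero atoms) in place of a group of 8 heavy atoms (7 carbon, 1 nitrogen; one six-membered aromatic ring with 1 hetero atom), on an amide-type nitrogen. Among the compounds with values here, the only step measured between compounds that differ in a single place is a step that the two limits leave unreadable from compound 2 to compound 3; its two ends are both limits and its size cannot be read. No measured step bears on the exchange from compound 1 to compound 4, and no direction can be taken from the data shown. The estimate for compound 4 in this assay is 28000 nM, with a range from 10000 nM to 60000 nM. The step that this estimate means, a 1.3-fold higher number from compound 1 to compound 4 (0.11 log units; within the scatter), is expected to stay within the scatter of repeated measurements.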

Compound 4, half-maximal cytotoxic concentration: 16000 nM
The estimate for compound 4 lay 1.8-fold (0.24 log units) above the measured number; measured number inside the range.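

Going by these compounds alone, the exchange on the amide-type nitrogen gives the first step in this set that can be read, a 1.4-fold lower number from compound 1 to compound 4 (0.14 log units; within the scatter), in this assay. The 1-(pyridin-4-yl)ethyl group and the group of 11 heavy atoms, with its five-membered aromatic ring, therefore cannot be told apart in this assay, although the two groups differ in ring size, atom count and hydrogen-bond acceptors. No measurement shown gives a reason for this result.

This single pair says nothing about other groups at this position, so a plain phenyl ring, a simple amine or a longer chain ending in a carboxylic acid could behave differently. As far as these compounds go, it also remains open whether the same exchange would give a similar result on a core with other groups elsewhere.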